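A few compounds are considered here, and "the series" means these few. Any claim that something is new, unique, unknown or untested is made for them only; others in the source may bear on it.

Measured in a functional assay on M21 cells (Homo sapiens) for antiproliferative activity, read by sulforhodamine B assay, with a stated time of 48 h; a lower number here means a stronger inhibitor, a higher number a weaker inhibitor:
- compound 1 `CCCN1CCN(c2ccc(S(=O)(=O)Oc3cc(Cl)c(Cl)cc3Cl)cc2)C1=O`: 15000 nM
- compound 2 `CCCN1CCN(c2ccc(S(=O)(=O)Oc3cccc(OC)c3)cc2)C1=O`: 10000 nM
- compound 3 `CCCN1CCN(c2ccc(S(=O)(=O)Oc3cccc(Cl)c3)cc2)C1=O`: 8600 nM

In this assay, compound 2 stands at 10000 nM and is not separated from the other two compounds. The steps that reach it are a 1.5-fold lower number from compound 1 to compound 2 (0.18 log units; within the scatter) and a 1.2-fold lower number from compound 2 to compound 3 (0.07 log units; within the scatter), both within the scatter, so no order can be read among these three values.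

Compound 4 `CCCCN1CCN(c2ccc(S(=O)(=O)Oc3cccc(OC)c3)cc2)C1=O` differs from compound 2 by methyl in place of hydrogen on a saturated chain carbon, three bonds along the chain from an amide-type nitrogen in a ring. In words, the propyl chain becomes butyl, and the rest of the structure is unchanged.

For the measured compounds named here, no measured step touches this chain, since all three compounds carry propyl. The available steps change only the group on the oxygen or its substituent. Besides the two above, there is a 1.7-fold lower number from compound 1 to compound 3 (0.24 log units; within the scatter), also within the scatter. These steps bear on the change only indirectly: they show a flat series at this end of the molecule, and they give no measure of what chain length does. With no chain data, no direction can be assigned, and no shift beyond the scatter is expected in this assay.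

The expected result is a 1.1-fold lower number from compound 2 to compound 4 (0.05 log units; within the scatter), which is no real change. For compound 4 the estimated half-maximal inhibitory concentration is 9000 nM, with an expected range of 4000 nM to 20000 nM.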

Compound 4, half-maximal inhibitory concentration: 30000 nM
Compound 4: middle estimate off by 3.3-fold (0.52 log units), on the low side; the whole stated range lies below it.
By their numbers in this assay, from the lowest: compounds 3, 2, 1 and 4 (each within the scatter of the next, the first and the last beyond it).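

In this assay, going from propyl to butyl on the ring's amide-type nitrogen gives a 3.0-fold higher number from compound 2 to compound 4 (0.48 log units; beyond the scatter) and so moves the number towards a weaker inhibitor. For the compounds shown here, this is the first step to pass beyond the scatter, whereas every step so far at the group on the oxygen stayed within it, so the chain position responds where the changes at the other end of the molecule could not be told apart. The reading rests on a single pair with the 3-methoxyphenyl group on the oxygen, and nothing available accounts for the size or the direction of this step.

On these data alone, with only propyl and butyl in hand, it remains open whether ethyl or pentyl on the same nitrogen, or a chain ending in an amine or a carboxylic acid, would follow the same direction. As far as these compounds go, it is also open whether the butyl chain has a similar effect when 3-chlorophenyl or 2,4,5-trichlorophenyl sits on the oxygen.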